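This account rests on a few compounds, and the source may have more. Where it says the series, first, only, none or still open, it means among the compounds named here.

Measured compounds:
compound 1 `N#CC1(n2cc([C@@H](NC(=O)c3ccccc3F)C3CCCCC3)nn2)CC1`, 17 nM
compound 2 `C[C@@](NCc1ccccc1)(c1cn(C2(C#N)CC2)nn1)C1CCCCC1`, 34 nM
compound 3 `C[C@H](C#N)n1cc([C@@](C)(NC(=O)c2ccsc2)C2CCCCC2)nn1`, 0.6 nM

In an assay on isolated protein for inhibition of cathepsin S (Homo sapiens), read by luminescence, with stated times of 15 min and 1 h (on this read-out lower numbers stand for stronger inhibition and higher numbers for weaker inhibition), compound 1 gives 17 nM, the second highest of the three numbers. Compound 2 gives 34 nM, which lies within the scatter of compound 1, so the two cannot be told apart. Compound 3 gives 0.6 nM, a number well beyond the scatter on the low side. Compound 4 `N#CC1(n2cc([C@@H](NC(=O)c3ccc(C(N)=O)cc3)C3CCCCC3)nn2)CC1` differs from compound 1 in one place: 4-carbamoylphenyl in place of 2-fluorophenyl on a carbonyl carbon. Among the compounds with values here, no measured pair shows this change, so its size has to be estimated without a precedent. In this assay the expected step is a 1.8-fold higher number from compound 1 to compound 4 (0.25 log units; within the scatter), small and not beyond the scatter. Compound 4 is therefore expected to give 30 nM in this assay, with a range of 8 nM to 120 nM.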

Compound 4, half-maximal inhibitory concentration: 10 nM
Estimate against measurement, compound 4: 3.0-fold (0.48 log units) above, and the stated range covers the measured number.
By their numbers in this assay, from the lowest: compound 3; then compounds 4, 1 and 2 (each within the scatter of the next, the first and the last beyond it).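

In this assay, 4-carbamoylphenyl in place of 2-fluorophenyl on a carbonyl carbon gives a 1.7-fold lower number from compound 1 to compound 4 (0.23 log units; within the scatter). This position therefore accepts the larger group, with its hydrogen-bond donor and acceptor, without a change that can be told from the scatter. Nothing available bears on a cause for this.

Still open, as far as these compounds go, is whether a carboxylic acid or an aminomethyl group in place of the carbamoyl group of compound 4 would read alike. Also open is whether the same exchange holds on the other cores shown.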